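Aryl in Place of Ethyl on the Ring Nitrogen

The source may report more compounds than this note shows. Statements on the series, on what has been measured and on what is new or still open speak of the compounds shown alone.

Measured compounds:
compound 1, `CCN1C(=O)CSC1c1cccc(C(=O)NCCCCc2ccccc2)c1`: 13%
compound 2, `O=C(NCCCCc1ccccc1)c1cccc(C2OCC(=O)N2c2cccc(F)c2)c1`: 25%

Two compounds were measured in a functional assay on U2OS cells (Homo sapiens) for inhibition, read by CCK-8 assay, with a stated time of 72 h, tested at 1 uM; a higher number here means more inhibition at the concentration tested (going by the name of the read-out), a lower number less inhibition. Compound 1 gives 13%, the lower of the two numbers. Compound 2 gives 25%, a figure higher than that of compound 1 by more than the usual scatter. Within the data shown here, both compounds carry the same amide chain on the shared core; compound 2 differs in the five-membered ring and in the group on its ring nitrogen, so no single-change step between them can be drawn.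

Compound 3, `COc1c(F)cccc1N1C(=O)CSC1c1cccc(C(=O)NCCCCc2ccccc2)c1`, is not yet measured. It differs from compound 1 in one place: 3-fluoro-2-methoxyphenyl in place of ethyl on an amide-type nitrogen in a ring. Compound 2, which also bears an aromatic group on the ring nitrogen, gives 25%, and that is the only hint available. A modest rise is expected in this assay, a number 12 percentage points higher from compound 1 to compound 3 (beyond the scatter), though it may not exceed the scatter. Compound 3 is therefore estimated at 25%, with a range from 5% to 45%.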

Compound 3, a percentage reported as inhibition, at one concentration (the size of the read-out at that concentration, not a potency): 12%
Compound 3: middle estimate off by 13 percentage points, on the high side; the measured number falls inside the stated range.
By their numbers in this assay, from the lowest: compounds 3 and 1 (each within the scatter of the next); then compound 2.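

In this assay, among these compounds, 3-fluoro-2-methoxyphenyl in place of ethyl on the amide-type nitrogen in the ring gives a number 1 percentage points lower from compound 1 to compound 3 (within the scatter) and so provides the first single-change reading at this position. It shows that, at the one concentration tested, this much larger aromatic group and ethyl cannot be told apart. Among the compounds shown here, the step concerns only this pair and gives no potency for either compound. Nothing measured here accounts for the result.

On these data alone, it remains open whether a plain phenyl, a pyridine ring, or a short chain ending in an amine or a carboxylic acid on this nitrogen would give a number beyond the scatter from that of compound 1. Also open, as far as these compounds go, is what the fluorine and the methoxy each contribute on their own within the 3-fluoro-2-methoxyphenyl group.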